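Sulfonyl aryl variation on the shared core: working notes

A few compounds are considered here, and "the series" means these few. Any claim that something is new, unique, unknown or untested is made for them only; others in the source may bear on it.

Measured so far in a functional assay on MCF7 cells (Homo sapiens) for antiproliferative activity, read by MTT assay, with a stated time of 72 h; on this read-out higher numbers stand for weaker inhibition and lower numbers for stronger inhibition:
compound 1 `Cc1ccc(S(=O)(=O)NCc2cn(C[C@H](O)[C@H]3OC(=O)C(OCc4ccccc4)=C3OCc3ccccc3)nn2)cc1`: 6400 nM
compound 3 `O=C1O[C@H]([C@@H](O)Cn2cc(CNS(=O)(=O)c3ccc(Cl)cc3F)nn2)C(OCc2ccccc2)=C1OCc1ccccc1`: 3390 nM
compound 2 `O=C1O/C(=C\Cn2cc(-c3cc(F)cc(F)c3)nn2)C(OCc2ccccc2)=C1OCc1ccccc1`: > 100000 nM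

In this assay compound 1 gives 6400 nM, the highest of the two numbers reported; the nearest is compound 3, at 3390 nM. Compound 2 gives no number in this assay, only the limit > 100000 nM (the limit of > 100000 nM in this assay, at which 1 of the 3 values shown sits). Among the compounds with values here, the one measured step that touches the aryl on the sulfonyl sulfur is a 1.9-fold lower number from compound 1 to compound 3 (0.28 log units; within the scatter), and it stays within the scatter of the method.

Compound 4 `O=C1O[C@H]([C@@H](O)Cn2cc(CNS(=O)(=O)c3ccc(F)cc3)nn2)C(OCc2ccccc2)=C1OCc1ccccc1` is the next entry in the set. It differs from compound 1 by fluoro in place of methyl on an aromatic carbon. Within the data shown here, no measured pair isolates this exact exchange; the only related comparison, a 1.9-fold lower number from compound 1 to compound 3 (0.28 log units; within the scatter), exchanges the whole aryl and still moves the number less than the scatter. The change in compound 4 is smaller in count than that one, so no move beyond the scatter is expected in this assay, and the expected step is a 1.2-fold lower number from compound 1 to compound 4 (0.07 log units; within the scatter). Compound 4 is therefore estimated at 5500 nM, with a range from 2200 nM to 14000 nM.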

Compound 4, half-maximal inhibitory concentration: 26800 nM
Compound 4: the middle estimate sits 4.9-fold (0.69 log units) below what was measured; measured number above the stated range.
By their numbers in this assay, from the lowest: compounds 3 and 1 (each within the scatter of the next); then compound 4. At a limit, above all of these: compound 2.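

In this assay the aryl on the sulfonyl sulfur now proves sensitive to a single small exchange: fluoro in place of methyl on an aromatic carbon, para to a large group, gives a 4.2-fold higher number from compound 1 to compound 4 (0.62 log units; beyond the scatter) and moves the number beyond the scatter, which the earlier step at this aryl did not do. The exchange of the whole aryl gives a 7.9-fold higher number from compound 3 to compound 4 (0.90 log units; beyond the scatter) with the same direction and also lies beyond the scatter, yet compound 3 carries fluoro within its 4-chloro-2-fluorophenyl group, so the presence of fluoro on the ring does not by itself go with the higher number. No measured property among the data shown bears on this rise, so it stands as an observation without an assigned cause.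

The compounds shown leave open whether the rise is particular to 4-fluorophenyl, which a plain phenyl, a 4-chlorophenyl or a 4-methoxyphenyl on the sulfonyl sulfur would help to settle. They also leave open how this position responds to a group of a different kind, such as an amine or a carboxylic acid on the same aryl.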